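Compound 1 to compound 4: bromo in place of nitro

A few compounds are considered here, and "the series" means these few. Any claim that something is new, unique, unknown or untested is made for them only; others in the source may bear on it.

Measured in a functional assay on HCT-116 cells (Homo sapiens) for antiproliferative activity, read by MTT assay, with a stated time of 48 h; a lower number here means a stronger inhibitor, a higher number a weaker inhibitor:
compound 1 `COc1ccc(CN(C(=O)CSc2nc3ccccc3s2)c2cc(OC)c(OC)c(OC)c2)cc1[N+](=O)[O-]` gives 1280 nM
compound 2 `COc1ccc2nc(SCC(=O)N(Cc3ccc(OC)c(O)c3)c3cc(OC)c(OC)c(OC)c3)sc2c1` gives 352 nM
compound 3 `COc1ccc(CN(C(=O)CSc2nc3cc(Cl)ccc3s2)c2cc(OC)c(OC)c(OC)c2)cc1O` gives 429 nM

Compound 1 holds the highest of the three numbers, and its gaps to compound 2 and to compound 3 both lie beyond the scatter. Compound 4 `COc1ccc(CN(C(=O)CSc2nc3ccccc3s2)c2cc(OC)c(OC)c(OC)c2)cc1Br` is still to be measured in this assay. It differs from compound 1 as follows: bromo in place of nitro on an aromatic carbon. The same change reads 4-methoxy-3-nitrobenzyl to 3-bromo-4-methoxybenzyl.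

Going by the values given here, no measured step touches this place. The only one, a 1.2-fold higher number from compound 2 to compound 3 (0.09 log units; within the scatter), concerns the group on the sulfur and so gives no size for the change at hand. Compound 2 and compound 3 carry neither nitro nor bromo at this place and differ from compound 1 in more than one place, so they offer only a loose guide. With that caution, the lower numbers of compound 2 at 352 nM and compound 3 at 429 nM lead to the expectation of a modest move to a lower number in this assay, with little confidence in its size. The expected step is a 2.1-fold lower number from compound 1 to compound 4 (0.33 log units; beyond the scatter). Compound 4 is estimated at 600 nM, with an expected range from 200 nM to 1800 nM.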

Compound 4, half-maximal inhibitory concentration: 4550 nM
Beside the measured number, compound 4's estimate is 7.6-fold (0.88 log units) below it; the whole stated range lies below it.
By their numbers in this assay, from the lowest: compounds 2 and 3 (each within the scatter of the next); then compound 1; then compound 4.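

In this assay, bromo in place of nitro on this aromatic carbon, ortho to a methoxy group, gives a 3.6-fold higher number from compound 1 to compound 4 (0.55 log units; beyond the scatter). Going by these compounds alone, this is the first measured step at this position and shows that the position responds to the change of group, whereas the only earlier step, a 1.2-fold higher number from compound 2 to compound 3 (0.09 log units; within the scatter), concerned the group on the sulfur and lay within the scatter. No supporting measurement accompanies the result, so the reason for the step remains unknown.

The compounds shown leave open how an amine or a nitrile on this aromatic carbon would compare with nitro and bromo on the core of compound 1, and how the hydroxy group found at this place in compound 2 and compound 3 would read on that same core. Also open, on these data alone, is whether the step from nitro to bromo keeps its size when the group on the sulfur changes to the substituted groups carried by compound 2 and compound 3.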